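A few compounds are considered here, and "the series" means these few. Any claim that something is new, unique, unknown or untested is made for them only; others in the source may bear on it.

Measured compounds:
compound 1, `CCN(CC)Cc1cc(-c2ccccc2)n(Nc2ccnc3cc(Cl)ccc23)c1C`, 3620 nM in an ADME assay on K562 cells (Homo sapiens) for cytotoxicity, read by MTT assay; a lower number here means a stronger inhibitor, a higher number a weaker inhibitor;
compound 2, `Cc1cc(CNC(C)(C)C)c(C)n1Nc1ccnc2cc(Cl)ccc12`, "not determined" (no result reported) in this assay;
compound 3, `Cc1c(CNC(C)(C)C)cc(-c2ccccc2)n1Nc1ccnc2cc(Cl)ccc12`, "not determined" (no result reported) in this assay.

Three compounds share a core, and only compound 1 carries a number in this assay. Compound 3 stands without a single number there, and compound 2 is a further entry without one, so nothing can be said of how compound 3 compares with either neighbour on the numbers shown. Among the measured compounds shown here, the one firm point is compound 1, which gives 3620 nM in this assay.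

Compound 4, `Cc1c(CNCC[C@@H]2CCCN3CCCC[C@H]23)cc(-c2ccccc2)n1Nc1ccnc2cc(Cl)ccc12`, is the next compound to be measured in this assay. It differs from compound 3 in one place: a group of 12 heavy atoms (11 carbon, 1 nitrogen; 2 six-membered non-aromatic rings with 1 hetero atom each) in place of a group of 4 heavy atoms (4 carbon; no ring), on an amine nitrogen. For the measured compounds named here, no step between measured compounds is available to weigh this change. Given only the number for compound 1, the expectation is that compound 4 lands near that same region, with no step beyond the usual scatter foreseen in either direction.

Compound 4 is estimated at 3500 nM in this assay, with a range from 1000 nM to 12000 nM.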

Compound 4, half-maximal inhibitory concentration: 2610 nM
Beside the measured number, compound 4's estimate is 1.3-fold (0.13 log units) above it; the range from low to high includes it.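

Compound 4 gives 2610 nM in this assay, yet no new step can be read; compound 3 has no single number there to compare. No evidence shown bears on this result. Going by these compounds, what exchanging the tert-butyl group does to the value remains open.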